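Anilinoquinazoline thioacetamides: trimethoxyphenyl variant expected

The source may hold more compounds than are shown below. What is called first, only, known or untested is meant among the compounds shown, and "the series" means these compounds.

Of the compounds shown here, two have numbers so far. Compound 1 `O=C(CSc1nc(Nc2ccccc2)c2ccccc2n1)Nc1ccccc1F` in a functional assay on NCI-H1975 cells (Homo sapiens) for inhibition, read by MTT assay, with a stated time of 72 h (on this read-out higher numbers stand for weaker inhibition and lower numbers for stronger inhibition), gives 9350 nM. Compound 2 `C=CC(=O)Nc1cccc(NC(=O)CSc2nc(Nc3ccccc3F)c3ccccc3n2)c1` in this assay gives 6580 nM. Going by the values given here, these two numbers sit within the scatter of each other, so they read as the same level of inhibition, and compound 1 and compound 2 differ in more than one place, which leaves no single-change step to build on.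

Compound 3 `C=CC(=O)Nc1cccc(NC(=O)CSc2nc(Nc3cc(OC)c(OC)c(OC)c3)c3ccccc3n2)c1` is not yet measured in this assay. Relative to compound 2 it carries 3,4,5-trimethoxyphenyl in place of 2-fluorophenyl on a nitrogen on an aromatic ring. Nothing in the measured pair tells how the nitrogen on the aromatic ring responds to a group of this size, so the step from compound 2 to compound 3 is expected to be a 1.1-fold lower number from compound 2 to compound 3 (0.04 log units; within the scatter) in this assay, that is, no shift beyond the scatter in either direction, with the range kept wide for the uncertainty. The estimate for compound 3 in this assay is 6000 nM, between 1500 nM and 25000 nM.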

Compound 3, half-maximal inhibitory concentration: > 50000 nM
Compound 3: only a limit was reported; the forecaster's own chance of this, stated with the estimate: 10%; middle value at least 8.3-fold (0.92 log units) away from the limit.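

On the nitrogen on an aromatic ring, the group is not neutral in this assay: 3,4,5-trimethoxyphenyl in place of 2-fluorophenyl gives an at least 7.5-fold higher number from compound 2 to compound 3 (0.88 log units; beyond the scatter), the only single-place step among the compounds shown and one that points to weaker inhibition. Compound 1 and compound 2 sit within the scatter of each other but differ in more than one place, so they gave no reading of this position on its own. Compound 3 gives > 50000 nM, which is a limit of the assay and not a number, so the step fixes only a minimum size and its true extent stays unknown: the limit of > 50000 nM in this assay, at which 1 of the 3 values shown sits.

The change brings in 12 heavy atoms and 3 hydrogen-bond acceptors where 2-fluorophenyl has 7 heavy atoms and 0 hydrogen-bond acceptors, and this single step does not separate those differences from one another. As far as these compounds go, whether the loss follows from the three methoxy groups together stays open, as does the response of this position to a phenyl ring with one methoxy group or to a plain cyclohexyl ring.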